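Swapping the amide substituent on a weak nuclease inhibitor

The source may hold more compounds than are shown below. What is called first, only, known or untested is meant among the compounds shown, and "the series" means these compounds.

Compound 1 `CNC(=O)c1nc(-c2cccs2)[nH]c(=O)c1O` carries a methyl group on its amide-type nitrogen. In an assay on isolated protein for inhibition of deoxyribonuclease-1 (Homo sapiens) (on this read-out higher numbers stand for weaker inhibition and lower numbers for stronger inhibition), compound 1 gives 67600 nM. Compound 2 `CCC(C)NC(=O)c1nc(-c2cccs2)[nH]c(=O)c1O` has a sec-butyl group in the same place. In this assay, on these data alone, compound 2 reaches only the limit of the measurement, > 100000 nM, so its true number is unknown. The step of an at least 1.4-fold higher number from compound 1 to compound 2 (0.17 log units; that floor lies within the scatter) can therefore be sized only at its floor, and that floor sits inside the usual scatter, as the limit of > 100000 nM in this assay, at which 1 of the 2 values shown sits, shows. Compound 3 `CC(=O)NCCNC(=O)c1nc(-c2cccs2)[nH]c(=O)c1O` is not yet measured. It differs from compound 2 by 2-acetamidoethyl in place of sec-butyl on an amide-type nitrogen. Among the measured compounds shown here, only the step from compound 1 to compound 2 bears on this change, and it did not exceed the scatter. In this assay the expected step is therefore a number no higher from compound 2 to compound 3 (the limit leaves the size open), nothing beyond the scatter. Compound 3 is thus expected to sit near 100000 nM, within 30000 nM to 300000 nM.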

Compound 3, half-maximal inhibitory concentration: 62600 nM
Beside the measured number, compound 3's estimate is 1.6-fold (0.20 log units) above it; measured number inside the range.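

In this assay, compound 3 shows that a chain much larger than methyl can sit on this amide-type nitrogen and still give a measured number rather than a limit. Replacing methyl with 2-acetamidoethyl gives a 1.1-fold lower number from compound 1 to compound 3 (0.03 log units; within the scatter), so this larger group leaves inhibition where it was with methyl. Against sec-butyl, the change gives an at least 1.5-fold lower number from compound 2 to compound 3 (0.20 log units; that floor lies within the scatter), and its true size stays unknown because compound 2 stands at a limit: the limit of > 100000 nM in this assay, at which 1 of the 3 values shown sits.

On these data alone, whether sec-butyl really weakens inhibition therefore remains open, as its step from methyl also cannot be sized beyond the floor. As far as these compounds go, it is also open whether a chain ending in an amine or a carboxylic acid, or a longer plain carbon chain, would move the number beyond the scatter.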